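A few compounds are considered here, and "the series" means these few. Any claim that something is new, unique, unknown or untested is made for them only; others in the source may bear on it.

In an ADME assay on HT-29 cells (Homo sapiens) for cytotoxicity, read by MTT assay, with a stated time of 72 h (on this read-out higher numbers stand for weaker inhibition and lower numbers for stronger inhibition), three compounds have been read so far, and none of them yields a number. Compound 1 (`COc1ccc(C2=C(c3cc(OC)c(OC)c(OC)c3)C(=O)CC2C)cc1C(=O)O`) gives > 100 ug/mL as a limit of the assay. Compound 2 (`COc1ccc(C2=C(c3cc(OC)c(OC)c(OC)c3)C(=O)CC2O[SiH2]C(C)(C)C)cc1`) gives > 100 ug/mL as a limit too. Compound 3 (`COc1cc(C2=C(c3cc(C)c(OC)c(C)c3)C(OC(C)=O)CC2=O)cc(OC)c1OC`) gives > 100 ug/mL as a limit as well. Compound 2 therefore stands with the other two, and the whole set comes down to the limit of > 100 ug/mL in this assay, at which 3 of the 3 values shown sit, with no measured number among them.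

Compound 4 (`COC(=O)c1cc(C2=C(c3cc(OC)c(OC)c(OC)c3)C(=O)CC2O[SiH2]C(C)(C)C)ccc1OC`) differs from compound 2 by methoxycarbonyl in place of hydrogen on an aromatic carbon on an aromatic carbon, where methoxycarbonyl takes the place of hydrogen, ortho to a methoxy group. The 4-methoxyphenyl thus becomes 4-methoxy-3-(methoxycarbonyl)phenyl. Within the data shown here, no measured pair shows this change in this assay so the expectation is of no step beyond the scatter, in either direction. The expected move is a number no higher from compound 2 to compound 4 (the limit leaves the size open) and no more than that. For compound 4 the estimate is 100 ug/mL with an expected range from 50 ug/mL to 200 ug/mL on this read-out, and a further report of only a limit is quite likely.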

Compound 4, half-maximal inhibitory concentration: > 100 ug/mL
Compound 4: a limit, no number (the forecaster's own chance of this, stated with the estimate: 70%); the middle value lies on the limit itself.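

In this assay compound 4 gives > 100 ug/mL, which is a limit and not a number. Compound 2 also stands at a limit, so no step can be read between compound 2 and compound 4. The compounds shown leave open what number any of them would give, and so what methoxycarbonyl in place of hydrogen does: the limit of > 100 ug/mL in this assay, at which 4 of the 4 values shown sit.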